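A few compounds are considered here, and "the series" means these few. Any claim that something is new, unique, unknown or untested is made for them only; others in the source may bear on it.

The study sets two measured compounds beside one not yet measured. Compound 1 `COc1ccc(-c2cc(/C=C/C(=O)c3ccc(N)cc3)[nH]n2)cc1` and compound 2 `COc1cc(-c2cc(/C=C/C(=O)c3ccc(N)cc3)[nH]n2)cc(OC)c1OC` share a common core and differ only in the methoxy groups on one aromatic ring. In a functional assay on HCT-116 cells (Homo sapiens) for inhibition, read by sulforhodamine B assay, with a stated time of 48 h (on this read-out lower numbers stand for stronger inhibition of growth and higher numbers for weaker inhibition of growth), compound 1 gives 3610 nM, and in this assay compound 2 gives 2610 nM. Compound 2 holds the lower of the two numbers, yet its gap to compound 1 lies within the scatter of repeated measurements, so neither can be ranked above the other. Compound 3 `COc1ccc(-c2cc(/C=C/C(=O)c3ccc(N)cc3)[nH]n2)cc1OC` is reached from compound 2 by a single change: hydrogen in place of methoxy on an aromatic carbon. Among the compounds with values here, no step of this kind has been measured here, so the expectation rests on the two values alone, which sit close together. The step is expected to be small, a 1.1-fold higher number from compound 2 to compound 3 (0.06 log units; within the scatter), with no direction beyond the scatter. Compound 3 is therefore estimated at 3000 nM, with a likely range from 1500 nM to 6500 nM.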

Compound 3, concentration for total growth inhibition: 3510 nM
Compound 3: middle estimate off by 1.2-fold (0.07 log units), on the low side; the measured number falls inside the stated range.
By their numbers in this assay, from the lowest: compounds 2, 3 and 1 (each within the scatter of the next).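

In this assay, hydrogen in place of methoxy gives a 1.3-fold higher number from compound 2 to compound 3 (0.13 log units; within the scatter) and methoxy in place of hydrogen gives a 1.0-fold lower number from compound 1 to compound 3 (0.01 log units; within the scatter) as the two single changes on the aromatic ring. These steps show that exchanging hydrogen and methoxy on an aromatic carbon, ortho to a methoxy group and meta to a large group, stays within the scatter in both of these settings, which the earlier pair could not show, since those compounds differ in more than one place. Nothing available explains the size of these steps.

Still open, going by these compounds, is whether another group on this carbon, such as a hydroxyl group, an amine or a carboxylic acid, would give a step beyond the scatter. Also open, on these data alone, is whether these steps would stay as small on a ring carrying no other methoxy group.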